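The compounds below may be only part of what the source reports. "The series", "measured", "known", "first", "only" and "open" are said of these compounds alone.

Measured so far:
compound 1 `N#CC1=C(N)N(c2ccc(S(N)(=O)=O)cc2)C2=C(C(=O)CCC2)C1c1ccc(O)cc1` — 100%
compound 2 `COc1ccccc1C1C(C#N)=C(N)N(c2ccc(S(N)(=O)=O)cc2)C2=C1C(=O)CCC2` — 0%

In a functional assay on Ehrlich cells (Mus musculus) for antiproliferative activity, read by trypan blue exclusion, with a stated time of 2 h, tested at 100 ug/mL (on this read-out lower numbers stand for a weaker effect and higher numbers for a stronger effect at the one concentration tested), compound 2 gives 0%, the lower of the two numbers, and compound 1 gives 100%. Compound 3 `COc1ccc(C2C(C#N)=C(N)N(c3ccc(S(N)(=O)=O)cc3)C3=C2C(=O)CCC3)cc1` differs from compound 2 in a single place: 4-methoxyphenyl in place of 2-methoxyphenyl on a saturated ring carbon. Among the measured compounds shown here, the only measured step that bears on this is a number 100 percentage points lower from compound 1 to compound 2 (beyond the scatter), yet that step altered both the group on the phenyl and the spot where it sits, so it cannot separate the two effects. Compound 3 resembles compound 1 in where its substituent sits and compound 2 in the substituent itself, so the direction is genuinely open. The estimate for compound 3 is 50% (range 0% to 100%), meaning an expected step of a number 50 percentage points higher from compound 2 to compound 3 (beyond the scatter).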

Compound 3, a percentage reported as activity, at one concentration (the size of the read-out at that concentration, not a potency): 100%
For compound 3 the middle estimate is 50 percentage points below the measured one; the measured number falls inside the stated range.
By their numbers in this assay, from the lowest: compound 2; then compounds 1 and 3 (each within the scatter of the next).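

Moving the methoxy group alone gives in this assay a number 100 percentage points higher from compound 2 to compound 3 (beyond the scatter) even though the atoms stay the same, which the earlier step could not show because it changed two things at once. Placing a methyl on the oxygen of the 4-hydroxyphenyl group gives no change at the digits printed from compound 1 to compound 3 (within the scatter) and so leaves the read-out unmoved. Among these compounds, the loss therefore goes with the 2-methoxyphenyl arrangement, not with the methyl itself. Nothing available explains this difference. On these data alone, whether a 2-hydroxyphenyl, 4-aminophenyl or 4-chlorophenyl group would keep the effect remains open.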